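Carbamate in Place of Urea on a Shared Core

This account rests on a few compounds, and the source may have more. Where it says the series, first, only, none or still open, it means among the compounds named here.

Of the compounds shown here, three sharing one core have been measured in a functional assay on Shh Light II cells (Mus musculus) for inhibition, read by a luciferase reporter; on this read-out lower numbers stand for stronger inhibition and higher numbers for weaker inhibition. Compound 2, `N#Cc1ccccc1NC(=O)N1CCC(c2nc(-c3ccc4ccccc4n3)no2)CC1`, gives 190 nM. Compound 1, `C[C@H]1C[C@H](c2nc(-c3ccc4ccccc4n3)no2)CCN1C(=O)Nc1ccccc1Cl`, gives 900 nM, the highest of the three numbers and therefore the weakest inhibition in this set. Compound 3, `O=C(NC1CCCCC1)N1CCN(c2nc(-c3ccc4ccccc4n3)no2)CC1`, gives 53 nM, the lowest of the three. Compound 2 thus stands second highest: its gap to compound 3 and its gap to compound 1 both lie beyond the usual scatter of repeated measurements, so compound 2 is clearly weaker than compound 3 and clearly stronger than compound 1.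

The next compound, compound 4, `COc1ccccc1OC(=O)N1CCC(c2nc(-c3ccc4ccccc4n3)no2)CC1`, has not yet been measured. Compared with compound 2 the change is 2-methoxyphenoxy in place of (2-cyanophenyl)amino on a carbonyl carbon, so the carbonyl that links the ring nitrogen to the outer aromatic ring now carries an oxygen rather than a nitrogen on its far side.

Going by the values given here, no pair of measured compounds differing only in one place is available, so the size of this step cannot be read from the data. The expectation is a modest weakening, a step of a 2.4-fold higher number from compound 2 to compound 4 (0.37 log units; beyond the scatter) in this assay of about the size of the scatter or somewhat beyond it. Compound 4 is therefore estimated at 450 nM, with a range from 120 nM to 2000 nM.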

Compound 4, half-maximal inhibitory concentration: 250 nM
Estimate against measurement, compound 4: 1.8-fold (0.26 log units) above; the range from low to high includes it.
By their numbers in this assay, from the lowest: compound 3; then compounds 2 and 4 (each within the scatter of the next); then compound 1.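

Going by these compounds alone, this is the first step in the set that can be read at a single place: in this assay, a 1.3-fold higher number from compound 2 to compound 4 (0.12 log units; within the scatter), so the two compounds cannot be told apart on this read-out. The group on the carbonyl carbon can therefore be (2-cyanophenyl)amino, with 1 hydrogen-bond donor, or 2-methoxyphenoxy, with 0 hydrogen-bond donors, and this pair shows that a donor in this group is not needed for inhibition at this level. Nothing available explains why the two groups give results this close.

This single step replaces the nitrogen with an oxygen on the far side of the carbonyl and replaces the nitrile-bearing ring with a methoxy-bearing ring at once, so it leaves open what each replacement does alone, a question that the 2-cyanophenoxy and (2-methoxyphenyl)amino groups would separate. Also open, going by these compounds, is whether a group without an aromatic ring, such as a butoxy chain, would be tolerated on the same carbonyl carbon.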